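Metabolic stability: exchange at the branching carbon of compound 3

The source may report more compounds than this note shows. Statements on the series, on what has been measured and on what is new or still open speak of the compounds shown alone.

Measured compounds:
compound 1 `CC(C)C(Cc1nnc[nH]1)c1ccc(-c2ccc3cccc(F)c3c2)[nH]c1=O` — 0.307 h
compound 2 `Cc1nc(C(c2ccc(-c3ccc4cccc(F)c4c3)[nH]c2=O)C(C)C)[nH]c1C` — 0.268 h
compound 3 `CC(C)C(c1noc(=O)[nH]1)c1ccc(-c2ccc3cccc(F)c3c2)[nH]c1=O` — > 3 h

In an ADME assay on microsomes from liver (Homo sapiens) for metabolic stability (on this read-out higher numbers stand for a longer-lived compound and lower numbers for a shorter-lived compound), compound 1 gives 0.307 h and compound 2 gives 0.268 h. For compound 3 the reported value is a limit of the assay, > 3 h. Among the measured compounds shown here, compound 3 is the one compound that sits at the limit of > 3 h in this assay, at which 1 of the 3 values shown sits. It stands at the top of the measured set, with an at least 9.7-fold higher number from compound 1 to compound 3 (0.98 log units; beyond the scatter) and an at least 11-fold higher number from compound 2 to compound 3 (1.04 log units; beyond the scatter). Compound 4 `CC(C)C(/C=C1\CCNC1=O)c1ccc(-c2ccc3cccc(F)c3c2)[nH]c1=O` differs from compound 3 in one place: a group of 7 heavy atoms (5 carbon, 1 nitrogen, 1 oxygen; one five-membered non-aromatic ring with 1 hetero atom) in place of a group of 6 heavy atoms (2 carbon, 2 nitrogen, 2 oxygen; one five-membered aromatic ring with 3 hetero atoms), on a saturated chain carbon bound to an aromatic carbon and a saturated chain carbon. For the measured compounds named here, the group that enters has no measured counterpart here; the two measured steps show only that the group leaving carries the high numbers of the set, so a drop is expected, estimated as an at least 3.0-fold lower number from compound 3 to compound 4 (0.47 log units; beyond the scatter). Compound 4 is thus estimated at 1 h, between 0.3 h and 3 h.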

Compound 4, half-life: 0.713 h
Estimate against measurement, compound 4: 1.4-fold (0.15 log units) above; measured number inside the range.
By their numbers in this assay, from the lowest: compounds 2 and 1 (each within the scatter of the next); then compound 4. At a limit, above all of these: compound 3.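

At the saturated chain carbon bound to an aromatic carbon and a saturated chain carbon, a five-membered non-aromatic ring lifts the half-life clear of both low compounds, with a 2.3-fold higher number from compound 1 to compound 4 (0.37 log units; beyond the scatter) and a 2.7-fold higher number from compound 2 to compound 4 (0.42 log units; beyond the scatter). The five-membered aromatic ring with 3 hetero atoms still leads, with an at least 4.2-fold lower number from compound 3 to compound 4 (0.62 log units; beyond the scatter). The value of compound 3 is a limit of the assay: the limit of > 3 h in this assay, at which 1 of the 4 values shown sits.

Going by these compounds, how far compound 3 lies above the others stays open. Also open, on these data alone, is what a carboxylic acid or an amine on this carbon would give.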